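Dimethylamino in place of phenoxy at the para position

This account rests on a few compounds, and the source may have more. Where it says the series, first, only, none or still open, it means among the compounds named here.

Two compounds of the shared core have been run in a functional assay on SNB-19 cells (Homo sapiens) for inhibition, read by sulforhodamine B assay, with a stated time of 48 h; on this read-out higher numbers stand for weaker inhibition of growth and lower numbers for stronger inhibition of growth. Compound 1 `COc1cc(C)cc(-c2c(-c3ccnc(-c4ccc(C(C)=O)cc4)c3)cnn2CC#N)c1` returns only a limit there: compound 1 gives > 100000 nM, which is a limit of the assay and not a number. Among the measured compounds shown here, compound 2 `Cc1cc(O)cc(-c2nn(CC#N)cc2-c2ccnc(-c3ccc(Oc4ccccc4)cc3)c2)c1` gives 1070 nM in this assay, and this is the only actual number in the set. The other entry is a limit, (the limit of > 100000 nM in this assay, at which 1 of the 2 values shown sits), so compound 2 has no measured neighbour against which a step could be read. Compound 3 `Cc1cc(O)cc(-c2nn(CC#N)cc2-c2ccnc(-c3ccc(N(C)C)cc3)c2)c1` carries the change (dimethylamino in place of phenoxy on an aromatic carbon), that is, dimethylamino in place of phenoxy on an aromatic carbon, para to a large group. For the measured compounds named here, no measured pair shows this change, and compound 1 differs from compound 2 in more than one place, so no direction can be taken from the two values shown. The expected step from compound 2 to compound 3 is a 1.9-fold higher number from compound 2 to compound 3 (0.27 log units; within the scatter) in this assay, a small loss that may well sit within the usual scatter. Compound 3 is expected to give 2000 nM, with a range from 500 nM to 8000 nM.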

Compound 3, concentration for 50% growth inhibition: 4540 nM
Compound 3: the middle estimate sits 2.3-fold (0.36 log units) below what was measured; measured number inside the range.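

In this assay, among the compounds shown here, the change from phenoxy to dimethylamino on an aromatic carbon, para to a large group, gives the first readable step at this position: a 4.2-fold higher number from compound 2 to compound 3 (0.63 log units; beyond the scatter). The position is therefore sensitive to the group it carries, yet the six-membered aromatic ring of the phenoxy is not required for a measurable effect, since compound 3 still gives a number, 4540 nM, and not a limit of the assay. Nothing in the data shown gives a reason for this step, and a single pair cannot separate the loss of the ring from the exchange of oxygen for nitrogen on the aromatic carbon.

Still open, from the compounds shown here alone, is whether phenylamino, which keeps the ring and places nitrogen on the aromatic carbon, would read closer to compound 2 or to compound 3, and whether methoxy, which keeps the oxygen without the ring, would do the same. Morpholine and piperidine at the same carbon would show whether a cyclic amine follows dimethylamino or departs from it.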